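Swapping the Amine Substituent: What Cytotoxicity to Expect

The source may report more compounds than this note shows. Statements on the series, on what has been measured and on what is new or still open speak of the compounds shown alone.

The account begins with compound 1 `CC(C)CN(CC(C)C)N1CCN(c2nc(=O)c3cc(C(F)(F)F)cc([N+](=O)[O-])c3s2)CC1`. In an ADME assay on Vero cells (Chlorocebus sabaeus) for cytotoxicity, read by MTT assay, with a stated time of 72 h (on this read-out higher numbers stand for lower toxicity in this test and lower numbers for higher toxicity in this test), compound 1 gives > 64 ug/mL, which is a limit of the assay rather than a measured number. Compound 2 `CON=C1CCC(N(C)N2CCN(c3nc(=O)c4cc(C(F)(F)F)cc([N+](=O)[O-])c4s3)CC2)CC1` gives > 64 ug/mL in this assay, again a limit. Compound 3 `O=c1nc(N2CCN(NCc3ccc(Cl)cc3)CC2)sc2c([N+](=O)[O-])cc(C(F)(F)F)cc12` gives > 64 ug/mL in this assay, also a limit. The steps between these three, a step that the two limits leave unreadable from compound 1 to compound 2, a step that the two limits leave unreadable from compound 1 to compound 3 and a step that the two limits leave unreadable from compound 2 to compound 3, therefore cannot be read in size or direction, and the only firm point is the limit of > 64 ug/mL in this assay, at which 3 of the 3 values shown sit.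

The compound still to be measured is compound 4 `O=c1nc(N2CCN(Nc3ccc(C(F)(F)F)cc3)CC2)sc2c([N+](=O)[O-])cc(C(F)(F)F)cc12`. It differs from compound 1 at a single site: (4-(trifluoromethyl)phenyl)amino in place of diisobutylamino on an amine nitrogen in a ring. The two measured steps leaving compound 1 each replace the diisobutylamino group on the same amine nitrogen in a ring with a different group, and both end at the same limit, so neither gives a readable size. On that evidence no step beyond the usual scatter is expected for compound 4 in this assay, in either direction. Compound 4 is accordingly estimated at 80 ug/mL, with a range from 32 ug/mL to 200 ug/mL. The corresponding step that the limit leaves unreadable from compound 1 to compound 4 is expected to be small.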

Compound 4, half-maximal cytotoxic concentration: > 64 ug/mL
Compound 4: only a limit was reported; the forecaster's own chance of this, stated with the estimate: 75%; the middle value is on the limit's open side.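

In this assay compound 4 gives > 64 ug/mL, which is again a limit. The steps to compound 4 from compound 1, compound 2 and compound 3 therefore cannot be read in size or direction. The compounds shown leave open whether these amine substituents differ at all in cytotoxicity, since the only firm point remains: the limit of > 64 ug/mL in this assay, at which 4 of the 4 values shown sit.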